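Nitrophenyl positional change in the cytotoxicity series

A few compounds are considered here, and "the series" means these few. Any claim that something is new, unique, unknown or untested is made for them only; others in the source may bear on it.

Compound 3 `CCOC(=O)c1cnc(N2CCN(Cc3ccc([N+](=O)[O-])cc3)CC2)nc1Oc1c(C)cc(-c2ccc(C#N)cc2)cc1C` returns in an ADME assay on MT4 cells (Homo sapiens) for cytotoxicity, read by MTT assay, with a stated time of 4 days (a lower number here means that less compound is tolerated, a higher number that more compound is tolerated), only a limit, > 125000 nM. Compound 1 `CCOC(=O)c1cnc(N2CCN(Cc3cccc(C(=O)OC)c3)CC2)nc1Oc1c(C)cc(-c2ccc(C#N)cc2)cc1C` likewise reaches only the limit, > 125000 nM. Compound 2 `CCOC(=O)c1cnc(N2CCN(Cc3ccccc3C(=O)OC)CC2)nc1Oc1c(C)cc(-c2ccc(C#N)cc2)cc1C` also sits at the limit, > 125000 nM. All three values rest on the one limit (the limit of > 125000 nM in this assay, at which 3 of the 3 values shown sit), so the steps a step that the two limits leave unreadable from compound 1 to compound 2, a step that the two limits leave unreadable from compound 1 to compound 3 and a step that the two limits leave unreadable from compound 2 to compound 3 cannot be read in size. Compound 4 `CCOC(=O)c1cnc(N2CCN(Cc3cccc([N+](=O)[O-])c3)CC2)nc1Oc1c(C)cc(-c2ccc(C#N)cc2)cc1C` is not yet measured; it differs from compound 3 by 3-nitrophenyl in place of 4-nitrophenyl on a saturated chain carbon bound to an amine nitrogen in a ring. For the measured compounds named here, no measured step covers this change directly, and the measured steps give no readable size, so no shift beyond the scatter is expected and compound 4 is expected to return the same limit. The expected step of a number no higher from compound 3 to compound 4 (the limit leaves the size open) is estimated as flat. For compound 4 the estimate in this assay is 125000 nM, within 60000 nM to 250000 nM.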

Compound 4, half-maximal cytotoxic concentration: > 125000 nM
Compound 4: a limit, no number; the forecaster's own chance of this, stated with the estimate: 85%; the middle value lies on the limit itself.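

Compound 4 gives > 125000 nM, a limit and not a number, so its steps from compound 1, compound 2 and compound 3 cannot be read: the limit of > 125000 nM in this assay, at which 4 of the 4 values shown sit.

The compounds shown leave open whether the change from 4-nitrobenzyl to 3-nitrobenzyl, or any other change among them, shifts the tolerated concentration in this assay.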